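Trimming a Methyl from the Morpholine Ring

This account rests on a few compounds, and the source may have more. Where it says the series, first, only, none or still open, it means among the compounds named here.

Of the compounds shown here, two have so far been measured in an assay on RKO cells for inhibition of ubiquitin carboxyl-terminal hydrolase 7 (Homo sapiens), read by a luciferase reporter, with a stated time of 18 h; on this read-out lower numbers stand for an effect already at smaller amounts and higher numbers for an effect only at larger amounts of compound. Compound 1 `Cc1cc(Cl)cc(-c2ccnc3cc(CN4C(=O)CCC4=O)sc23)c1O[C@H]1C[C@H](N)C1` gives 150 nM in this assay. Compound 2 `Cc1cc(Cl)cc(-c2ccnc3cc(CN4C(=O)C5CC5C4=O)sc23)c1C[C@@H]1CNC[C@@H](C)O1` gives 60 nM in this assay. Compound 2 therefore stands at the lowest of the two numbers, and its gap to compound 1 lies beyond the usual scatter. Compound 3 `Cc1cc(Cl)cc(-c2ccnc3cc(CN4C(=O)C5CC5C4=O)sc23)c1C[C@@H]1CNCCO1` has not yet been measured. It differs from compound 2 in one place only: hydrogen in place of methyl on a saturated ring carbon. For the measured compounds named here, no measured pair shows this exact change, so there is no step to lean on. Without such a guide, the expectation is that the number changes little, if at all, beyond the scatter, with a modest weakening the more likely direction. Compound 3 is expected to give about 80 nM, within a range from 35 nM to 200 nM. The expected step of a 1.3-fold higher number from compound 2 to compound 3 (0.12 log units; within the scatter) is accordingly small.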

Compound 3, half-maximal effective concentration: 35 nM
Compound 3: the middle estimate sits 2.3-fold (0.36 log units) above what was measured, and the stated range covers the measured number.
By their numbers in this assay, from the lowest: compounds 3 and 2 (each within the scatter of the next); then compound 1.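

In this assay, putting hydrogen in place of methyl on this saturated ring carbon, next to the ring oxygen, gives a 1.7-fold lower number from compound 2 to compound 3 (0.23 log units; within the scatter) and so makes no change that can be told apart from repeat-measurement scatter. For the compounds shown here, this is the first direct reading at this position: with the rest of the molecule held the same, the (morpholin-2-yl)methyl group does as well in this assay as the (6-methylmorpholin-2-yl)methyl group, so the methyl is not required to keep the number at this level. Nothing shown gives a reason for this result.

One methyl-to-hydrogen pair cannot show how this carbon responds to other groups, such as an ethyl, a hydroxymethyl or a fluorine. It also leaves open whether the same change would read alike with a different group on the shared core.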